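Swapping the Ring on the Amine Nitrogen: Compound 4 Expected

This account rests on a few compounds, and the source may have more. Where it says the series, first, only, none or still open, it means among the compounds named here.

Three measured compounds share one core and differ only in the group on an amine nitrogen in a ring. Compound 1 `O=C(/C=C/c1ccccc1)c1ccc(N2CCN(c3ccc(Cl)c(Cl)c3)CC2)cc1` carries a 3,4-dichlorophenyl there; in a functional assay on the whole organism (strain Kunming) for inhibition, with Mus musculus as the target, with a stated time of 1 h, at a dose of 40 mg/kg by the oral route (a lower number here means less inhibition, a higher number more inhibition at the dose given (going by the name of the read-out)), compound 1 gives 13.4%. Compound 2 `O=C(/C=C/c1ccccc1)c1ccc(N2CCN(c3ccc([N+](=O)[O-])cc3)CC2)cc1` carries a 4-nitrophenyl, and in this assay compound 2 gives 55.4%. Compound 3 `O=C(/C=C/c1ccccc1)c1ccc(N2CCN(c3ccccc3F)CC2)cc1` carries a 2-fluorophenyl, and in this assay compound 3 gives 0.57%. Compound 1 thus stands second highest of the three numbers. The two measured steps away from it run in opposite directions: a number 42 percentage points higher from compound 1 to compound 2 (beyond the scatter), and a number 12.8 percentage points lower from compound 1 to compound 3 (beyond the scatter). Compound 4 `Cc1ccc(N2CCN(c3ccc(C(=O)/C=C/c4ccccc4)cc3)CC2)cc1` is the next step from compound 1: 4-methylphenyl in place of 3,4-dichlorophenyl on an amine nitrogen in a ring. Among the measured compounds shown here, no measured step puts a 4-methylphenyl in this place, so the steps from compound 1 show only that changing this ring can move the number a long way either up or down. With nothing pointing one way, the expected step of a number 1.6 percentage points higher from compound 1 to compound 4 (within the scatter) is small, with a wide range. Compound 4 is therefore estimated at 15%, between 0% and 45%.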

Compound 4, a percentage reported as inhibition, in the whole organism at one dose (the size of the read-out at that dose, not a potency): 2.85%
Compound 4: middle estimate off by 12.2 percentage points, on the high side; the range from low to high includes it.
By their numbers in this assay, from the lowest: compounds 3 and 4 (each within the scatter of the next); then compound 1; then compound 2.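

In this assay, the 4-methylphenyl and the 4-nitrophenyl differ only by one group on an aromatic carbon, yet that change gives a number 52.6 percentage points lower from compound 2 to compound 4 (beyond the scatter), so the high number does not carry over to this other group on the aromatic ring. The other two steps give a number 10.6 percentage points lower from compound 1 to compound 4 (beyond the scatter) and a number 2.3 percentage points higher from compound 3 to compound 4 (within the scatter), which leaves the 4-methylphenyl and 2-fluorophenyl indistinguishable, and among these four compounds only the 4-nitrophenyl has a large step to each of the others. No measurement here explains this difference.

Going by these compounds, it remains open whether the high number is specific to nitro, or whether a nitrile or an amine on the aromatic ring would give a similar number. The plain phenyl, with no group on the ring, would provide a further point of comparison.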